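The source may report more compounds than this note shows. Statements on the series, on what has been measured and on what is new or still open speak of the compounds shown alone.

Compound 2, `CC1CCCN(C(=O)CN2CN(c3ccccc3)C3(CCN(C(=O)c4ccc(C(C)(C)C)cc4)CC3)C2=O)C1`, gives 12000 nM in an assay on HEK293 cells for displacement of a labelled ligand from NPC1-like intracellular cholesterol transporter 1 (Homo sapiens) (on this read-out higher numbers stand for weaker inhibition and lower numbers for stronger inhibition), the highest of the three numbers measured. Within the data shown here, compound 1, `CC1CCCN(C(=O)CN2CN(c3ccccc3)C3(CCN(C(=O)c4ccc(C5CCCCC5)cc4)CC3)C2=O)C1`, gives 3600 nM, and the step of a 3.3-fold higher number from compound 1 to compound 2 (0.52 log units; beyond the scatter) is the only change in this set that moves the number beyond the scatter. Compound 3, `CC(C)(C)OC(=O)NCC1CCCN(C(=O)CN2CN(c3ccccc3)C3(CCN(C(=O)c4ccc(C(C)(C)C)cc4)CC3)C2=O)C1`, gives 9500 nM, and the step of a 1.3-fold lower number from compound 2 to compound 3 (0.10 log units; within the scatter) lies within the scatter.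

Compound 4, `CC(C)(C)c1ccc(C(=O)N2CCC3(CC2)C(=O)N(CC(=O)N2CCCCC2CO)CN3c2ccccc2)cc1`, differs from compound 2 in the ring that sits on the carbonyl carbon: 2-(hydroxymethyl)piperidin-1-yl in place of 3-methylpiperidin-1-yl on a carbonyl carbon. Among the measured steps, only the step from compound 2 to compound 3 touches this part of the molecule, since it also alters a group on the saturated ring carried by that carbonyl, and it stayed within the scatter. Among the measured compounds shown here, no measured step tests a hydroxymethyl group or a change at this exact ring, so the expectation rests on that single comparison. On this basis compound 4 is expected to stay close to compound 2, with a step of a 1.2-fold lower number from compound 2 to compound 4 (0.08 log units; within the scatter) in this assay that is not expected to exceed the scatter. The estimated value for compound 4 is 10000 nM, with a range from 4000 nM to 25000 nM.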

Compound 4, half-maximal inhibitory concentration: 11800 nM
The estimate for compound 4 lay 1.2-fold (0.07 log units) below the measured number; the measured number falls inside the stated range.
By their numbers in this assay, from the lowest: compound 1; then compounds 3, 4 and 2 (each within the scatter of the next).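

Replacing 3-methylpiperidin-1-yl with 2-(hydroxymethyl)piperidin-1-yl on the carbonyl carbon gives a 1.0-fold lower number from compound 2 to compound 4 (0.01 log units; within the scatter) in this assay. The position therefore tolerates this swap, which adds an oxygen, a hydrogen-bond donor and a hydrogen-bond acceptor, without moving the number beyond the scatter. Compound 3 changed only a group carried on this ring, whereas compound 4 shows that the ring's own substituent can be exchanged with the same outcome. No measurement here helps explain this result.

Two things changed at once, the substituent and its ring position, so the effect of each stays unresolved; 2-methylpiperidin-1-yl or 3-(hydroxymethyl)piperidin-1-yl would separate them. From the compounds shown here alone, it also remains open whether a carboxylic acid or an amine on this ring would leave the number equally unmoved.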